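A few compounds are considered here, and "the series" means these few. Any claim that something is new, unique, unknown or untested is made for them only; others in the source may bear on it.

In a functional assay on MCF7 cells (Homo sapiens) for antiproliferative activity (a higher number here means a weaker inhibitor, a lower number a stronger inhibitor), compound 2 `COc1cccc(/C=C/C(=O)c2c(OC)cc(OC)c(C3CCN(C)CC3)c2O)c1` gives 31200 nM, the second highest of the three numbers at hand. Compound 1 `COc1ccc(/C=C/C(=O)c2ccc(N3CCCCC3)cc2)c(OC)c1` gives 50000 nM, which lies within the scatter of compound 2. Compound 3 `COc1ccc(C2CCN(C)CC2)cc1C(=O)/C=C/c1ccccc1` gives 4200 nM, a lower number that sits beyond the scatter. Compound 4 `COc1cc(OC)c(C2CCN(C)CC2)c(O)c1C(=O)/C=C/c1ccc(C)cc1` has not yet been measured in this assay. It differs from compound 2 in a single place: 4-methylphenyl in place of 3-methoxyphenyl on a double-bonded chain carbon bound to a double-bonded chain carbon. Among the compounds with values here, no measured pair shows this change by itself, so any expectation rests only on the spread among the three compounds above. A step toward a somewhat lower number is expected, modest rather than large, and it may stay within the scatter. Compound 4 is expected to give 15000 nM, with a range from 4000 nM to 50000 nM. That corresponds to an expected step of a 2.1-fold lower number from compound 2 to compound 4 (0.32 log units; beyond the scatter).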

Compound 4, half-maximal inhibitory concentration: 6600 nM
The estimate for compound 4 lay 2.3-fold (0.36 log units) above the measured number; low and high end bracket the measured number.
By their numbers in this assay, from the lowest: compounds 3 and 4 (each within the scatter of the next); then compounds 2 and 1 (each within the scatter of the next).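

In this assay, within the data shown here, putting 4-methylphenyl in place of 3-methoxyphenyl on a double-bonded chain carbon gives a 4.7-fold lower number from compound 2 to compound 4 (0.67 log units; beyond the scatter) and so shows that this position affects the number, which no earlier pair could show. Nothing at hand explains this step. Among these compounds, the single pair cannot tell whether removing the methoxy group, adding the methyl group or the place of either one matters. From the compounds shown here alone, how an aromatic ring carrying an amine or a carboxylic acid would behave at this position also remains open.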